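The source may report more compounds than this note shows. Statements on the series, on what has been measured and on what is new or still open speak of the compounds shown alone.

Measured in an ADME assay on Ava5 cells (Homo sapiens) for cytotoxicity; a higher number here means that more compound is tolerated, a lower number that less compound is tolerated:
compound 1 `NC(=S)Nc1cccc(OCCCCCCc2ccccc2)c1`: 28000 nM
compound 2 `NC(=S)Nc1cccc(OCCCCCOc2ccc(Cl)cc2)c1`: 7000 nM
compound 3 `NC(=S)Nc1cccc(OCCCCCOc2ccccn2)c1`: > 50000 nM, a limit and not a number

Compound 3 stands at a limit and has no number of its own: the limit of > 50000 nM in this assay, at which 1 of the 3 values shown sits.

Compound 4 `NC(=S)Nc1cccc(OCCCCCOc2cccnc2)c1` differs from compound 3 in one group: pyridin-3-yl in place of pyridin-2-yl on an oxygen on a saturated carbon. Pyridin-3-yl stands in place of pyridin-2-yl on an oxygen on a saturated carbon, so the two have the same atoms, joined differently.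

For the measured compounds named here, no measured step exchanges one pyridinyl group for another. The closest is an at least 7.1-fold higher number from compound 2 to compound 3 (0.85 log units; beyond the scatter), where pyridin-2-yl replaces 4-chlorophenyl at the same place. The two others are a 4.0-fold lower number from compound 1 to compound 2 (0.60 log units; beyond the scatter) and an at least 1.7-fold higher number from compound 1 to compound 3 (0.25 log units; that floor lies within the scatter). Among these three compounds, only the one carrying 4-chlorophenyl stands apart, as the step of an at least 7.1-fold higher number from compound 2 to compound 3 (0.85 log units; beyond the scatter) shows.

Compound 4 does not bring that group back, and it keeps a six-membered aromatic ring with 1 hetero atom. No step beyond the scatter is therefore expected in this assay, in either direction. The estimated step is an at least 1.2-fold lower number from compound 3 to compound 4 (0.09 log units; that floor lies within the scatter), and it may turn out to be only a limit again. Compound 4 is estimated at 40000 nM, with an expected range from 15000 nM to 70000 nM.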

Compound 4, half-maximal cytotoxic concentration: > 50000 nM
Compound 4 ended at the assay's limit (the forecaster's own chance of this, stated with the estimate: 45%); middle value at least 1.2-fold (0.09 log units) from the limit.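

In this assay, pyridin-3-yl in place of pyridin-2-yl on an oxygen on a saturated carbon leaves compound 4 at a limit and not a number, as compound 3 also is, so the step between these two cannot be read: the limit of > 50000 nM in this assay, at which 2 of the 4 values shown sit.

What compound 4 adds is that the gap to 4-chlorophenyl is not confined to a single pyridinyl isomer, as the change to pyridin-3-yl gives an at least 7.1-fold higher number from compound 2 to compound 4 (0.85 log units; beyond the scatter). The comparison with the benzyl end of compound 1 stays weaker, and the result there, an at least 1.7-fold higher number from compound 1 to compound 4 (0.25 log units; that floor lies within the scatter), is only a floor, which leaves the true size of that step unknown.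

The compounds shown leave open how far above the limit either pyridinyl compound would lie, and whether pyridin-4-yl at the same place would also reach it. They also leave open whether the chlorine or the phenyl ring sets compound 2 apart, a question that a plain phenyl or a chloropyridinyl group on the same oxygen could begin to answer.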